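Replacing morpholin-4-yl with 3-hydroxyazetidin-1-yl on a carbonyl carbon

The source may hold more compounds than are shown below. What is called first, only, known or untested is meant among the compounds shown, and "the series" means these compounds.

Results so far in a functional assay on HCT-116 cells (Homo sapiens) for inhibition; a lower number here means that less compound is needed, a higher number that more compound is needed for the effect
- Compound 1 `COc1cc(N2CCN(C(=O)C3CCC(O)CC3)CC2)ccc1Nc1nc(NC2CCCCC2)c2nc[nH]c2n1` gives 14 nM
- Compound 2 `COc1cc(N2CCN(CC3CCOC3)CC2)ccc1Nc1nc(NC2CCCCC2)c2nc[nH]c2n1` gives 170 nM
- Compound 3 `COc1cc(N2CCC(C(=O)N3CCOCC3)CC2)ccc1Nc1nc(NC2CCCCC2)c2nc[nH]c2n1` gives 130 nM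
- Compound 4 `COc1cc(N2CCC(C(=O)N3CC(O)C3)CC2)ccc1Nc1nc(NC2CCCCC2)c2nc[nH]c2n1` awaits measurement

Compound 3 stands second highest of the three numbers, within the scatter of compound 2 and well above compound 1. Compound 4 carries 3-hydroxyazetidin-1-yl in place of morpholin-4-yl on a carbonyl carbon. For the measured compounds named here, only one measured step bears on this, and only indirectly (a 12-fold higher number from compound 1 to compound 2 (1.08 log units; beyond the scatter)). That step is large, but it involves (oxolan-3-yl)methyl replacing (4-hydroxycyclohexyl)carbonyl on an amine nitrogen in a ring. A much smaller shift towards a lower number is therefore expected in this assay, and the estimated step is modest (a 2.2-fold lower number from compound 3 to compound 4 (0.34 log units; beyond the scatter)). The estimate for compound 4 is 60 nM (expected range 20 nM to 170 nM).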

Compound 4, half-maximal effective concentration: 260 nM
Beside the measured number, compound 4's estimate is 4.3-fold (0.64 log units) below it; the measured number lies above the stated range.
By their numbers in this assay, from the lowest: compound 1; then compounds 3, 2 and 4 (each within the scatter of the next).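

In this assay the exchange of morpholin-4-yl for 3-hydroxyazetidin-1-yl on a carbonyl carbon gives a 2.0-fold higher number from compound 3 to compound 4 (0.30 log units; within the scatter) and so stays within the scatter. At this position, then, a four-membered ring carrying a hydrogen-bond donor reads the same as the six-membered ring without one, within the scatter of this single pair. Nothing available explains this result. The compounds shown leave open how a simple dimethylamino group or a piperazin-1-yl group on this carbonyl carbon would read in this assay and whether the hydroxyl of the azetidine contributes at all.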